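A few compounds are considered here, and "the series" means these few. Any claim that something is new, unique, unknown or untested is made for them only; others in the source may bear on it.

In a functional assay on cells (Panel leukemia (Carcinoma cell lines), Homo sapiens) for inhibition (on this read-out lower numbers stand for stronger inhibition of growth and higher numbers for weaker inhibition of growth), compound 2 (`CN1C/C(=C\c2cccs2)C2=NN(C)C(c3cccs3)C2C1`) gives 87800 nM as its result. Compound 1 (`COc1ccc(/C=C2\CN(C)Cc3c2nc(O)c(C#N)c3-c2ccc(OC)cc2)cc1`) gives 80700 nM in the same test, and these two numbers lie within the usual scatter of each other, so they cannot be told apart. Compound 3 (`Cc1ccc(/C=C2\CN(C)CC3=C2OC(N)=C(C#N)C3c2ccc(C)cc2)cc1`) gives 17900 nM as its result, a number lower than that of compound 2 by more than the scatter. Compound 2 thus shares the upper end of these numbers with compound 1.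

The next compound, compound 4 (`CN1C/C(=C\c2cccs2)C2=NN(c3ccccc3)C(c3cccs3)C2C1`), keeps the core of compound 2 and changes one group, with phenyl in place of methyl on an amine nitrogen in a ring (the counted change). Within the data shown here, no two measured compounds differ in only one place, so the data do not show directly what this swap does. With compound 2 at 87800 nM near the top of the measured numbers, a small move towards stronger growth inhibition is expected, though perhaps none beyond the scatter. The estimated step is a 1.8-fold lower number from compound 2 to compound 4 (0.24 log units; within the scatter) and it stays within the scatter. For compound 4 the expected value is 50000 nM with an estimated range from 17000 nM to 100000 nM in this test.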

Compound 4, concentration for total growth inhibition: 52200 nM
For compound 4 the middle estimate is 1.0-fold (0.02 log units) below the measured one; low and high end bracket the measured number.
By their numbers in this assay, from the lowest: compound 3; then compounds 4, 1 and 2 (each within the scatter of the next).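

In this assay, among these compounds, compounds 2 and 4 form the first pair that differs in only one place, so this swap can now be read directly (a 1.7-fold lower number from compound 2 to compound 4 (0.23 log units; within the scatter)). The step lies within the scatter, which means the two compounds cannot be told apart in this test, even though phenyl brings a six-membered aromatic ring of carbon only to an amine nitrogen in a ring where methyl carried no ring. Nothing measured here explains why the two compounds read alike.

The pair leaves open whether any group on this nitrogen can move the number beyond the scatter, for instance a benzyl group, a longer chain such as butyl, or a phenyl ring carrying a carboxylic acid or an amine. It also leaves open whether the same swap would behave alike on the cores of compound 1 and compound 3, since each of those differs from this pair in more than one place and offers no comparison of this change.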